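Shortening the linker in a xanthine-type MAO-A series

A few compounds are considered here, and "the series" means these few. Any claim that something is new, unique, unknown or untested is made for them only; others in the source may bear on it.

Measured so far:
- compound 1 `Cc1ccc(CCSc2nc3c(c(=O)n(C)c(=O)n3C)n2C)cc1` — 125000 nM
- compound 2 `Cn1c(=O)c2c(nc(SCCc3cccc(Br)c3)n2C)n(C)c1=O` — 5700 nM

In an assay on microsomes for inhibition of Amine oxidase [flavin-containing] A (Homo sapiens), read by fluorescence and spectrophotometry, with a stated time of 20 min (on this read-out higher numbers stand for weaker inhibition and lower numbers for stronger inhibition), compound 2 gives the lowest of the two numbers seen, and the gap to compound 1 is large: a 22-fold lower number from compound 1 to compound 2 (1.34 log units; beyond the scatter). Within the data shown here, that one step is the only measured guide, and it concerns the substituent on the aromatic ring while the two-carbon chain to the sulfur stays the same.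

Compound 3 `Cn1c(=O)c2c(nc(SCc3cccc(Cl)c3)n2C)n(C)c1=O` is not yet measured. Relative to compound 2 it shows (3-chlorophenyl in place of 3-bromobenzyl on a saturated chain carbon bound to a sulfur), so both the halogen and the chain length change at once. Among the measured compounds shown here, no measured pair isolates the shorter chain, so the step from compound 1 to compound 2 bears only indirectly on it. The expected step of a 1.1-fold higher number from compound 2 to compound 3 (0.02 log units; within the scatter) is therefore set near no change, with a wide allowance either way. For compound 3 the estimate in this assay is 6000 nM, with a range from 1200 nM to 30000 nM.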

Compound 3, half-maximal inhibitory concentration: 6430 nM
Compound 3: middle estimate off by 1.1-fold (0.03 log units), on the low side; the range from low to high includes it.
By their numbers in this assay, from the lowest: compounds 2 and 3 (each within the scatter of the next); then compound 1.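

In this assay, putting 3-chlorophenyl in place of 3-bromobenzyl on a saturated chain carbon bound to a sulfur gives a 1.1-fold higher number from compound 2 to compound 3 (0.05 log units; within the scatter) and so no readable difference, although the entering group has 7 heavy atoms against 8 for the one leaving. Compound 3 also keeps the large separation from the first compound, with a 19-fold lower number from compound 1 to compound 3 (1.29 log units; beyond the scatter) in the same direction as the step to compound 2. Nothing on hand explains this result.

On these data alone, the halogen and the chain length change together between compound 2 and compound 3, so what each contributes alone stays open, and the two changes might even offset each other. Also open, as far as these compounds go, is what a longer chain, or a group carrying an amine, would do at this place.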